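The source may report more compounds than this note shows. Statements on the series, on what has been measured and on what is new or still open speak of the compounds shown alone.

Of the compounds shown here, two of the same core have been measured in a functional assay on MCF7 cells (Homo sapiens) for inhibition, read by colorimetric assay and MTT assay, with a stated time of 72 h; a higher number here means a weaker inhibitor, a lower number a stronger inhibitor. Compound 1, `COc1cc(C(=O)NNC(=S)Nc2csc(-c3ccc(C)cc3)c2)cc(OC)c1OC`, gives 31000 nM in this assay. Compound 2, `COc1cc(OC)cc(C(=O)NNC(=S)Nc2csc(-c3ccccc3)c2)c1`, gives 38000 nM in this assay, the higher of the two numbers, though the gap to compound 1 lies within the usual scatter of repeated measurements. Among the measured compounds shown here, no pair differing in a single place has yet been measured, so no step size is known for this series.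

The next compound, compound 3, has the structure `COc1cc(OC)cc(C(=O)NNC(=S)Nc2csc(-c3ccc(C)cc3)c2)c1`. It differs from compound 2 by methyl in place of hydrogen on an aromatic carbon. Since compound 2 sits within the scatter of compound 1, which carries the same 4-methylphenyl group and gives 31000 nM, the change is not expected to move this assay by more than the scatter. Compound 3 is therefore estimated at 33000 nM in this assay, with a likely range from 15000 nM to 70000 nM, which would make the expected step of a 1.2-fold lower number from compound 2 to compound 3 (0.06 log units; within the scatter) essentially flat.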

Compound 3, half-maximal inhibitory concentration: 26000 nM
Estimate against measurement, compound 3: 1.3-fold (0.10 log units) above; the range from low to high includes it.
By their numbers in this assay, from the lowest: compounds 3, 1 and 2 (each within the scatter of the next).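

In this assay, among the compounds shown here, the change from phenyl to 4-methylphenyl, methyl in place of hydrogen on an aromatic carbon para to a large group, gives a 1.5-fold lower number from compound 2 to compound 3 (0.16 log units; within the scatter) and is the first single-place change that can be read: at this position, methyl leaves the number within the scatter. Hydrogen in place of methoxy on an aromatic carbon, a change in a different place, gives a 1.2-fold lower number from compound 1 to compound 3 (0.08 log units; within the scatter) and so also stays within the scatter. Nothing available explains why either change leaves the number where it is.

The compounds shown leave open whether an amine, a carboxylic acid or a longer chain at the position of the methyl would move the number beyond the scatter. They also leave open whether a hydroxyl group in place of that methoxy would do so.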